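A few compounds are considered here, and "the series" means these few. Any claim that something is new, unique, unknown or untested is made for them only; others in the source may bear on it.

Measured compounds in a functional assay on CHO cells for agonist activity at Free fatty acid receptor 1 (Homo sapiens), read by FLIPR and calcium flux, tested at 1 uM; on this read-out higher numbers stand for an effect only at larger amounts of compound and lower numbers for an effect already at smaller amounts:
- compound 1 `Cc1ccc(C)c(OCc2nnc(C(=O)Nc3ccc(CCC(=O)O)cc3)s2)c1`: 1530 nM
- compound 2 `O=C(O)CCc1ccc(NC(=O)c2nnc(COc3ccc4c(c3)CCC4)s2)cc1`: 1380 nM
- compound 3 `Cc1ccc(OCc2nnc(C(=O)Nc3ccc(CCC(=O)O)cc3)s2)cc1C`: 1130 nM

All three share the same core and differ only in the aryl group carried on an oxygen on a saturated carbon. Compound 2 sits with the second highest of the three numbers; its nearest neighbour is compound 1, with a 1.1-fold lower number from compound 1 to compound 2 (0.04 log units; within the scatter), and its furthest is compound 3, with a 1.2-fold lower number from compound 2 to compound 3 (0.09 log units; within the scatter). The remaining pair shows a 1.4-fold lower number from compound 1 to compound 3 (0.13 log units; within the scatter). None of these steps exceeds the scatter, so the three values cannot be ordered.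

Compound 4 `Cc1ccccc1OCc1nnc(C(=O)Nc2ccc(CCC(=O)O)cc2)s1` is not yet measured. Relative to compound 2 the change is 2-methylphenyl in place of 2,3-dihydro-1H-inden-5-yl on an oxygen on a saturated carbon. Every measured step in the series is an exchange of the aryl group at this same position, and each of them stayed within the scatter. Within the data shown here, no step therefore gives grounds to expect a shift in this assay in either direction beyond the scatter for this further exchange.

On that basis compound 4 is expected to give about 1400 nM in this assay, with a range of 700 nM to 2800 nM, which means an expected step of a 1.0-fold higher number from compound 2 to compound 4 (0.01 log units; within the scatter).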

Compound 4, half-maximal effective concentration: 1520 nM
For compound 4 the middle estimate is 1.1-fold (0.04 log units) below the measured one, and the stated range covers the measured number.
By their numbers in this assay, from the lowest: compounds 3, 2, 4 and 1 (each within the scatter of the next).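

In this assay, the exchange of 2,3-dihydro-1H-inden-5-yl for the smaller 2-methylphenyl, which removes the five-membered non-aromatic ring, stays within the scatter, with a 1.1-fold higher number from compound 2 to compound 4 (0.04 log units; within the scatter), and the comparison with 3,4-dimethylphenyl does the same, with a 1.3-fold higher number from compound 3 to compound 4 (0.13 log units; within the scatter). The series also gains its first change within a single aryl group: hydrogen in place of methyl on an aromatic carbon, which gives a 1.0-fold lower number from compound 1 to compound 4 (0.00 log units; within the scatter), so at this position the second methyl makes no difference that can be read in this assay. Nothing available explains why these values stay so close.

Going by these compounds, all four aryl groups carry only carbon, so it remains open whether an aryl group bearing an amine, a nitrile or a methoxy group, or a saturated cyclohexyl group in its place, would stay within this narrow range. The compounds shown also leave open how the number responds to changes elsewhere on the shared core, such as replacing the carboxylic acid with a tetrazole or using a longer chain to carry it.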